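Enlarging the amine ring on the shared core

The source may hold more compounds than are shown below. What is called first, only, known or untested is meant among the compounds shown, and "the series" means these compounds.

Going by the values given here, compound 1 `CC(C(=O)NCc1ccc(C(F)(F)F)nc1NC1CCCCC1)c1ccc(NS(C)(=O)=O)c(F)c1` gives 260 nM in a functional assay on CHO-K1 cells for antagonist activity at transient receptor potential cation channel subfamily V member 1 (Homo sapiens), read by FLIPR (on this read-out lower numbers stand for stronger inhibition and higher numbers for weaker inhibition), the highest of the three numbers measured so far. Compound 2 `CC(C(=O)NCc1ccc(C(F)(F)F)nc1N1CCC(C)(C)CC1)c1ccc(NS(C)(=O)=O)c(F)c1` gives 8 nM, and compound 3 `CCCCOC1CCN(c2nc(C(F)(F)F)ccc2CNC(=O)C(C)c2ccc(NS(C)(=O)=O)c(F)c2)CC1` gives 28.2 nM. Compound 4 `CC(C(=O)NCc1ccc(C(F)(F)F)nc1N1CCCCCCC1)c1ccc(NS(C)(=O)=O)c(F)c1` differs from compound 1 in one place: a group of 8 heavy atoms (7 carbon, 1 nitrogen; one eight-membered non-aromatic ring with 1 hetero atom) in place of a group of 7 heavy atoms (6 carbon, 1 nitrogen; one six-membered non-aromatic ring of carbon only), on an aromatic carbon. Among the compounds with values here, two measured steps bear on this change, since both also replace the cyclohexylamino group of compound 1 with a six-membered non-aromatic ring with 1 hetero atom: a 33-fold lower number from compound 1 to compound 2 (1.51 log units; beyond the scatter) and a 9.2-fold lower number from compound 1 to compound 3 (0.96 log units; beyond the scatter). Both moved the number downward, one by a large and one by a modest step, so a large downward step is expected in this assay, although an eight-membered ring has not yet been tested. Compound 4 is therefore estimated at 20 nM, between 6 nM and 70 nM, which means a 13-fold lower number from compound 1 to compound 4 (1.11 log units; beyond the scatter).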

Compound 4, half-maximal inhibitory concentration: 27.8 nM
Estimate against measurement, compound 4: 1.4-fold (0.14 log units) below; measured number inside the range.
By their numbers in this assay, from the lowest: compound 2; then compounds 4 and 3 (each within the scatter of the next); then compound 1.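

In this assay, the eight-membered ring also gives a 9.4-fold lower number from compound 1 to compound 4 (0.97 log units; beyond the scatter) and so shows that the change from cyclohexylamino need not lead to a six-membered ring; compounds 2, 3 and 4 all have 0 hydrogen-bond donors in this group. Ring size still matters to the number, with a 3.5-fold higher number from compound 2 to compound 4 (0.54 log units; beyond the scatter) at equal heavy-atom count, yet there is a 1.0-fold lower number from compound 3 to compound 4 (0.01 log units; within the scatter) despite the different rings. Nothing available explains these steps. A cyclooctylamino group, which keeps the nitrogen's hydrogen, could separate ring size from donor loss. Azepane, the seven-membered ring, remains open too.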